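The source may report more compounds than this note shows. Statements on the series, on what has been measured and on what is new or still open speak of the compounds shown alone.

Working notes on the series. Among the measured compounds shown here, compound 1 `N#C/C(=C\c1ccc(Cl)cc1)C(=O)c1ccc[nH]1` gives 43000 nM in a functional assay on NCI-H460 cells (Homo sapiens) for inhibition, read by MTT assay, with a stated time of 72 h (on this read-out lower numbers stand for stronger inhibition of growth and higher numbers for weaker inhibition of growth), the only numerical value among the three measured compounds. Compound 2 `COc1ccc(CNC(=O)/C(C#N)=C/c2ccc[nH]2)cc1` reaches no number: in this assay compound 2 returns > 50000 nM, which is a limit of the assay and not a measured value. Compound 3 `N#C/C(=C\c1ccco1)C(=O)NCc1ccc(Cl)c(Cl)c1` likewise ends at a limit, giving > 50000 nM in this assay. For the measured compounds named here, compound 2 thus stands at the limit of > 50000 nM in this assay, at which 2 of the 3 values shown sit, and no step between compound 2 and any other measured compound is available.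

Compound 4 `COc1ccc(CNC(=O)/C(C#N)=C/c2ccc(C)o2)cc1` is not yet measured. It differs from compound 2 in one place: 5-methylfuran-2-yl in place of 1H-pyrrol-2-yl on a double-bonded chain carbon bound to a double-bonded chain carbon. With compound 2 itself at a limit, no direction for this change can be read from the series, and no step beyond the scatter is expected. The step from compound 2 to compound 4 in this assay is therefore estimated as a step that the limit leaves unreadable from compound 2 to compound 4. For compound 4 the expected value in this assay is 60000 nM, within a range of 20000 nM to 200000 nM, most probably reported again as a limit.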

Compound 4, concentration for 50% growth inhibition: > 100000 nM
Compound 4: no number, only a limit; the forecaster's own chance of this, stated with the estimate: 70%; at least 1.6-fold (0.22 log units) between middle value and limit.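

Compound 2 and compound 4 both end at limits in this assay, not at numbers, and the step between them cannot be read. The compounds shown leave open how 5-methylfuran-2-yl in place of 1H-pyrrol-2-yl changes growth inhibition, in either direction or at all.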